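The compounds below may be only part of what the source reports. "The series", "measured", "known", "first", "only" and "open" are said of these compounds alone.

In a functional assay on KG-1 cells (Homo sapiens) for cytotoxicity, read by luminescence and CellTiter-Glo, with a stated time of 3 days (a lower number here means a stronger inhibitor, a higher number a weaker inhibitor), three compounds built on a shared core have been measured. Compound 1 `N#Cc1ccc(NC(=O)c2cc(Br)c(-c3ccccc3)cc2O)cc1` gives 850 nM. Compound 3 `N#Cc1ccc(NC(=O)c2ccc3ccccc3c2O)cc1` gives 2720 nM. Compound 2 `COc1cccc(C(=O)Nc2ccc(C#N)cc2)c1O` reaches only a limit of the assay, > 10000 nM, so no number is known for it; it sits at the limit of > 10000 nM in this assay, at which 1 of the 3 values shown sits.

Compound 4 `N#Cc1ccc(NC(=O)c2ccccc2O)cc1` has not yet been measured. It differs from compound 2 in a single place: hydrogen in place of methoxy on an aromatic carbon.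

For the measured compounds named here, no measured pair here differs by just this change, so the size of the step in this assay cannot be read from the data. Because compound 2 itself stands only at a limit, a change in either direction is possible, and a move beyond the usual scatter cannot be ruled out, though compound 4 keeps less of what compound 1 and compound 3 carry. Compound 4 is expected to give about 8000 nM, with a likely range from 2500 nM to 25000 nM. That amounts to an expected step of an at least 1.2-fold lower number from compound 2 to compound 4 (0.09 log units; that floor lies within the scatter).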

Compound 4, half-maximal inhibitory concentration: 5370 nM
For compound 4 the middle estimate is 1.5-fold (0.17 log units) above the measured one, within the range that was stated.
By their numbers in this assay, from the lowest: compound 1; then compounds 3 and 4 (each within the scatter of the next). At a limit, above all of these: compound 2.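

In this assay, the carbon ortho to a hydroxy group now has its first reading for this change: putting hydrogen in place of methoxy there gives a step of an at least 1.8-fold lower number from compound 2 to compound 4 (0.27 log units; that floor lies within the scatter). Without the methoxy, compound 4 gives a true number that can be compared, which the methoxy-bearing compound could not provide. Compound 2 stands only at a limit of the assay, so just the floor of the step is known and the full step may be larger: the limit of > 10000 nM in this assay, at which 1 of the 4 values shown sits.

From the compounds shown here alone, whether an amine, a fluorine atom or a longer ether chain at this same carbon would give a lower or a higher number stays open. Going by these compounds, no step can be read from compound 4 to compound 1 or to compound 3, so what their extra groups contribute also remains open.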